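Aryl substituent survey on the spiro-oxindole triazole series

The source may hold more compounds than are shown below. What is called first, only, known or untested is meant among the compounds shown, and "the series" means these compounds.

Compound 1 `CCc1ccccc1-n1nncc1CN1C(=O)C2(C(C#N)=C(N)Oc3c(N)cc4nc5ccccc5nc4c32)c2ccccc21` gives 22900 nM in an ADME assay on L02 cells (Homo sapiens) for antiproliferative activity, read by MTT assay, with a stated time of 48 h; a higher number here means a weaker inhibitor, a lower number a stronger inhibitor. Compound 2 `N#CC1=C(N)Oc2c(N)cc3nc4ccccc4nc3c2C12C(=O)N(Cc1cnnn1-c1cccc(Br)c1)c1ccccc12` reaches only the limit > 50000 nM in this assay. Compound 3 `COc1ccc(-n2nncc2CN2C(=O)C3(C(C#N)=C(N)Oc4c(N)cc5nc6ccccc6nc5c43)c3ccccc32)cc1` likewise reaches only the limit > 50000 nM in this assay.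

Compound 3 thus sits at the limit, where two of the three values sit (the limit of > 50000 nM in this assay, at which 2 of the 3 values shown sit). Compound 4 `N#CC1=C(N)Oc2c(N)cc3nc4ccccc4nc3c2C12C(=O)N(Cc1cnnn1-c1ccc([N+](=O)[O-])cc1)c1ccccc12` differs from compound 3 by nitro in place of methoxy on an aromatic carbon. Within the data shown here, no measured step exchanges these two groups; the steps of an at least 2.1-fold higher number from compound 1 to compound 2 (0.33 log units; beyond the scatter) and an at least 2.1-fold higher number from compound 1 to compound 3 (0.33 log units; beyond the scatter) only show that leaving 2-ethylphenyl drives the number to the limit, and the step that the two limits leave unreadable from compound 2 to compound 3 cannot be read. Compound 4 is therefore expected to remain at or near the limit, a step of a number no higher from compound 3 to compound 4 (the limit leaves the size open) being no more than guessed. The estimate for compound 4 is 50000 nM (range 25000 nM to 120000 nM).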

Compound 4, half-maximal inhibitory concentration: > 50000 nM
Compound 4 gave a limit, no number; the forecaster's own chance of this, stated with the estimate: 70%; the middle value lies on the limit itself.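

Against 2-ethylphenyl, 4-nitrophenyl gives an at least 2.1-fold higher number from compound 1 to compound 4 (0.33 log units; beyond the scatter). Nitro in place of methoxy on an aromatic carbon leaves the reading at the limit, so the steps among compound 2, compound 3 and compound 4 cannot be read. Compound 1 remains the only one with a number in this assay: the limit of > 50000 nM in this assay, at which 3 of the 4 values shown sit.

Any real differences among those three compounds stay open, as does whether the ethyl group or its place on the ring sets compound 1 apart. Also open, going by these compounds, is how an amine, a carboxylic acid or a longer chain on the phenyl ring would read.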